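Swapping Isobutyl for Phenoxy: Expected Change in Solubility

A few compounds are considered here, and "the series" means these few. Any claim that something is new, unique, unknown or untested is made for them only; others in the source may bear on it.

Of the compounds shown here, three share one core and have been measured in a physicochemical assay for solubility, with a stated time of 18 h, at pH 7.4; on this read-out higher numbers stand for higher solubility and lower numbers for lower solubility. Compound 1, `COc1ccccc1Oc1ccc2c(NCCCNCc3ccco3)ccnc2c1`, carries a 2-methoxyphenoxy group on the core; in this assay compound 1 gives 14500 nM. Compound 2, `CC(C)Cc1ccc2c(NCCCNCc3ccco3)ccnc2c1`, carries an isobutyl group at that place instead; in this assay compound 2 gives 4200 nM. Compound 3, `COc1ccc(F)cc1CNCCCNc1ccnc2cc(Cc3cc(C)cc(C)c3)ccc12`, has a different arrangement of side groups; in this assay compound 3 gives 4200 nM. Compound 2 thus stands level with compound 3 at the digits shown, and the two together give the lowest numbers of the three, while compound 1 sits higher: a 3.5-fold lower number from compound 1 to compound 2 (0.54 log units; beyond the scatter).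

The unmeasured compound 4, `c1ccc(Oc2ccc3c(NCCCNCc4ccco4)ccnc3c2)cc1`, differs from compound 2 in one place: phenoxy in place of isobutyl on an aromatic carbon. For the measured compounds named here, this change is close to the reverse of the only measured step, which replaced a 2-methoxyphenoxy with an isobutyl and was modest but beyond the scatter, a 3.5-fold lower number from compound 1 to compound 2 (0.54 log units; beyond the scatter). Compound 4 lacks the methoxy present in compound 1; the reversal need not be complete. Given that step, compound 4 is expected to give a higher number, the estimated step being a 2.1-fold higher number from compound 2 to compound 4 (0.33 log units; beyond the scatter). Compound 4 is estimated at 9000 nM, with a likely range from 3500 nM to 25000 nM.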

Compound 4, solubility: 14500 nM
Beside the measured number, compound 4's estimate is 1.6-fold (0.21 log units) below it; measured number inside the range.
By their numbers in this assay, from the lowest: compounds 2 and 3 (each within the scatter of the next); then compounds 1 and 4 (each within the scatter of the next).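

In this assay, putting phenoxy in place of isobutyl on this aromatic carbon gives a 3.5-fold higher number from compound 2 to compound 4 (0.54 log units; beyond the scatter), so the change seen earlier in one direction now also appears with a simpler group that enters at the same place. For the compounds shown here, until now, the higher number at this position had been seen only with 2-methoxyphenoxy, which left open whether the methoxy group was needed for it. Placing hydrogen in place of that methoxy gives no change at the digits printed from compound 1 to compound 4 (within the scatter), so among these compounds the phenoxy group without the methoxy reaches the same printed number, and the methoxy makes no difference that can be read on this scale.

The compounds shown do not separate the oxygen that links the group to the core from the aromatic ring it carries, and a benzyl group, which keeps a six-membered aromatic ring but has carbon as the link, or an amine at this place would help tell those two parts apart. Nothing presented here gives a measured reason for the difference between isobutyl and phenoxy at this position.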